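Methyl in Place of Ethoxyethenyl: Expected Inhibition

The source may report more compounds than this note shows. Statements on the series, on what has been measured and on what is new or still open speak of the compounds shown alone.

Measured in an assay on FRT-Jurkat cells for inhibition of nuclear factor NF-kappa-B complex (Homo sapiens), read by flow cytometry, with a stated time of 24 h, tested at 10 uM; on this read-out lower numbers stand for less inhibition and higher numbers for more inhibition at the one concentration tested (going by the name of the read-out):
compound 1 `O=C1CCC(N2C(=O)c3cccc(Nc4ccccn4)c3C2=O)C(=O)N1` gives 1%
compound 2 `COc1ccc(Nc2cccc3c2C(=O)N(C2CCC(=O)NC2=O)C3=O)cc1` gives 13%
compound 3 `C=C(OCC)c1ccc(Nc2cccc3c2C(=O)N(C2CCC(=O)NC2=O)C3=O)cc1` gives 10%

Compound 3 sits within the usual scatter of compound 2 and also of compound 1, so none of the three is separated from compound 3 by more than the usual spread. Compound 4 `Cc1ccc(Nc2cccc3c2C(=O)N(C2CCC(=O)NC2=O)C3=O)cc1` differs from compound 3 by methyl in place of 1-ethoxyethenyl on an aromatic carbon. For the measured compounds named here, the one step that bears on this is the change at the same aromatic carbon, a number 3 percentage points lower from compound 2 to compound 3 (within the scatter), which stayed within the scatter. The earlier step of a number 12 percentage points higher from compound 1 to compound 2 (beyond the scatter) concerns a different part of the molecule and does not guide this change. A small group replacing a larger one at a spot where swapping groups made no difference suggests compound 4 is expected near compound 3, with a step of a number 1 percentage points higher from compound 3 to compound 4 (within the scatter) within the scatter. Compound 4 is estimated at 11%, between 2% and 20%.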

Compound 4, a percentage reported as inhibition, at one concentration (the size of the read-out at that concentration, not a potency): 9%
For compound 4 the middle estimate is 2 percentage points above the measured one; measured number inside the range.
By their numbers in this assay, from the lowest: compounds 1, 4, 3 and 2 (each within the scatter of the next, the first and the last beyond it).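

In this assay, a much smaller group on this aromatic carbon leaves the number level, without a readable change, with a number 1 percentage points lower from compound 3 to compound 4 (within the scatter) and a number 4 percentage points lower from compound 2 to compound 4 (within the scatter). Methyl with 1 heavy atom, 1-ethoxyethenyl with 5 and methoxy therefore cannot be told apart at this position. Changing pyridin-2-yl to 4-methylphenyl gives a number 8 percentage points higher from compound 1 to compound 4 (within the scatter), so this change stays within the scatter, whereas the change to 4-methoxyphenyl went beyond it.

No available evidence explains these results. On these data alone, whether an amine or a carboxylic acid on this aromatic carbon would move the number beyond the scatter remains open.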